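The compounds below may be only part of what the source reports. "The series", "measured", "known", "first", "only" and "open" are said of these compounds alone.

Working notes on the series.

Compound 1 `CC(C)(C)NC(=O)NCCS(=O)(=O)NC(=O)c1ccc(Nc2nc(NC3(c4ccc(Cl)cc4)CC3)nc(OCC(F)(F)F)n2)cc1` is one of the two highest of the three measured compounds in an ADME assay on microsomes from liver (Rattus norvegicus) for metabolic stability, with a stated time of 10 min; a lower number here means that less of the compound is left, a higher number that more of the compound is left: compound 1 gives 93%. Compound 2 `CC(C)(C)OC(=O)NCCS(=O)(=O)NC(=O)c1ccc(Nc2nc(NC3(c4ccc(Cl)cc4)CC3)nc(OCC(F)(F)F)n2)cc1` gives 93% in this assay, and the step of no change at the digits printed from compound 1 to compound 2 (within the scatter) leaves the number unchanged. Compound 3 `CS(=O)(=O)NC(=O)c1ccc(Nc2nc(NC3(c4ccc(Cl)cc4)CC3)nc(OCC(F)(F)F)n2)cc1`, which lacks the whole (((tert-butyl)carbamoyl)amino)methyl piece, gives 85%; the step of a number 8 percentage points lower from compound 1 to compound 3 (within the scatter) and the step of a number 8 percentage points lower from compound 2 to compound 3 (within the scatter) both stay inside the scatter. Across these three the number sits high and does not move beyond the scatter.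

Compound 4 `COC(=O)NCCS(=O)(=O)NC(=O)c1ccc(Nc2nc(NC3(c4ccc(Cl)cc4)CC3)nc(OCC(F)(F)F)n2)cc1` is not yet measured in this assay. Its change from compound 1 is methoxy in place of (tert-butyl)amino on a carbonyl carbon. The step that bears on it most directly is no change at the digits printed from compound 1 to compound 2 (within the scatter), an exchange at the same carbonyl carbon that produced no change; the removal of the whole group, a number 8 percentage points lower from compound 1 to compound 3 (within the scatter), also stayed within the scatter. No step beyond the scatter is therefore expected for a number 3 percentage points lower from compound 1 to compound 4 (within the scatter). For compound 4 a value of 90% is expected, in the range 78% to 98%.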

Compound 4, percent of the compound remaining: 100%
The estimate for compound 4 lay 10 percentage points below the measured number; the whole stated range lies below it.
By their numbers in this assay, from the lowest: compounds 3, 1, 2 and 4 (each within the scatter of the next, the first and the last beyond it).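

In this assay, the step of a number 15 percentage points higher from compound 3 to compound 4 (beyond the scatter) is the only one among these four compounds that lies beyond the scatter, so replacing hydrogen on the saturated chain carbon bound to a sulfonyl sulfur can separate two compounds when the entering group is ((methoxycarbonyl)amino)methyl. At the carbonyl carbon, the steps of a number 7 percentage points higher from compound 1 to compound 4 (within the scatter) and a number 7 percentage points higher from compound 2 to compound 4 (within the scatter) both remain within the scatter, so these exchanges do not separate compound 1, compound 2 and compound 4 from one another. No measurement available here accounts for the size of any of these steps.

On these data alone, it remains open whether a free amine, a carboxylic acid or a longer chain at this position would stay level with compound 4 or fall towards compound 3. The compounds shown also leave open whether any such step would exceed the scatter.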